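The source may report more compounds than this note shows. Statements on the series, on what has been measured and on what is new or still open speak of the compounds shown alone.

Measured compounds:
- Compound 1 `Cc1c(C2CCSCC2)c(=O)on1C(=O)N1CCCCC1`: in an assay (strain Wistar) for inhibition of Hormone-sensitive lipase (Rattus norvegicus), read by spectrophotometry (on this read-out lower numbers stand for stronger inhibition and higher numbers for weaker inhibition), compound 1 gives 11 nM
- Compound 2 `Cc1c(C2CCCCC2)c(=O)on1C(=O)N1CCC(C)CC1`: in this assay compound 2 gives 4 nM

Of the two numbers in hand, compound 2 stands at the lower one, and compound 1 sits above it by a gap the scatter of this assay does not cover. Among the measured compounds shown here, compound 1 and compound 2 differ in more than one place, so no single step links them, and what their two values show cannot be assigned to either place alone.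

Compound 3 `Cc1c(C2CCSCC2)c(=O)on1C(=O)N1CCC(C)CC1` is not yet measured in this assay. It is reached from compound 2 by one change: thian-4-yl in place of cyclohexyl on an aromatic carbon. The group that enters is the same one carried by compound 1, while the rest of compound 3 stays as in compound 2.

For the measured compounds named here, with no measured step for this change, the expectation rests on compound 1 and compound 2 alone. A step from compound 2 to compound 3 of a 2.0-fold higher number from compound 2 to compound 3 (0.30 log units; within the scatter) is expected, a small shift toward a higher number, barely if at all beyond the scatter. Compound 3 is therefore estimated at 8 nM, within a range of 3 nM to 25 nM.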

Compound 3, half-maximal inhibitory concentration: 6 nM
Estimate against measurement, compound 3: 1.3-fold (0.12 log units) above; measured number inside the range.
By their numbers in this assay, from the lowest: compounds 2, 3 and 1 (each within the scatter of the next, the first and the last beyond it).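

In this assay, thian-4-yl in place of cyclohexyl on the aromatic carbon next to the ring atom that bears a methyl group gives a 1.5-fold higher number from compound 2 to compound 3 (0.18 log units; within the scatter) and so, at this place, the two six-membered rings cannot be told apart, even though only the entering one holds a sulfur atom and counts a hydrogen-bond acceptor. Methyl in place of hydrogen on a saturated ring carbon gives a 1.8-fold lower number from compound 1 to compound 3 (0.26 log units; within the scatter) and is likewise not separated from the scatter, so the gap between compound 1 and compound 2, which lies beyond the scatter, is spanned only by the two changes taken together, while each alone stays within it. Nothing in hand accounts for these values.

The compounds shown leave open whether tetrahydropyran-4-yl, with a ring oxygen in place of the sulfur, or piperidin-4-yl, a ring amine, would fit this aromatic carbon as well as thian-4-yl does. Also open, going by these compounds, is what a smaller group such as isopropyl or a longer chain such as n-butyl would do there, and whether ethyl could stand in for the methyl on the saturated ring.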